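The source may report more compounds than this note shows. Statements on the series, on what has been measured and on what is new or still open speak of the compounds shown alone.

Measured so far in a functional assay on the whole organism for inhibition, with Rattus norvegicus as the target, at a dose of 50 mg/kg by the oral route; a higher number here means more inhibition at the dose given (going by the name of the read-out), a lower number less inhibition: compound 1 `CCOC(=O)c1c(CSc2ncc[nH]2)nc2cc(OC)c(OC)cc2c1-c1ccc(OC)c(OC)c1` gives 60%; compound 2 `CCOC(=O)c1c(CSc2nccn2CC)nc2cc(OC)c(OC)cc2c1-c1ccc(OC)c(OC)c1` gives 51%.

Compound 2 stands lowest of the two numbers in this assay, nearest compound 1, and the step of a number 9 percentage points lower from compound 1 to compound 2 (within the scatter) is within the scatter. Compound 3 `CCOC(=O)c1c(CS(=O)(=O)c2nccn2C)nc2cc(OC)c(OC)cc2c1-c1ccc(OC)c(OC)c1` differs from compound 2 by a group of 9 heavy atoms (4 carbon, 2 nitrogen, 2 oxygen, 1 sulfur; one five-membered aromatic ring with 2 hetero atoms) in place of a group of 8 heavy atoms (5 carbon, 2 nitrogen, 1 sulfur; one five-membered aromatic ring with 2 hetero atoms), on a saturated chain carbon bound to an aromatic carbon. Going by the values given here, no measured step touches the group on the saturated chain carbon bound to an aromatic carbon; the only step known, ethyl in place of hydrogen on an aromatic nitrogen, stayed within the scatter and bears little on this change. No shift beyond the scatter is expected. Compound 3 is estimated at 45% (20% to 70%), an expected step of a number 6 percentage points lower from compound 2 to compound 3 (within the scatter).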

Compound 3, a percentage reported as inhibition, in the whole organism at one dose (the size of the read-out at that dose, not a potency): 56%
For compound 3 the middle estimate is 11 percentage points below the measured one; the range from low to high includes it.
By their numbers in this assay, from the lowest: compounds 2, 3 and 1 (each within the scatter of the next).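

In this assay, the group on the saturated chain carbon bound to an aromatic carbon now has its first measured changes: (1-methyl-1H-imidazol-2-yl)sulfonyl gives a number 5 percentage points higher from compound 2 to compound 3 (within the scatter), and set against (1H-imidazol-2-yl)sulfanyl it gives a number 4 percentage points lower from compound 1 to compound 3 (within the scatter). Neither comparison moves the read-out beyond the scatter, so this place accepts the sulfonyl group without a resolved shift at this one dose. No available data bear on why.

Still open, on these data alone, is whether an amine or a carboxylic acid in place of (1-methyl-1H-imidazol-2-yl)sulfonyl would shift inhibition beyond the scatter. Also open, as far as these compounds go, is how these compounds compare across other doses.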